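This account rests on a few compounds, and the source may have more. Where it says the series, first, only, none or still open, it means among the compounds named here.

Of the compounds shown here, three sharing one core have been measured in a physicochemical assay for solubility, with a stated time of 18 h, at pH 7.4; a lower number here means a less soluble compound, a higher number a more soluble compound. Compound 1 `FC(F)(F)c1ccc(-c2ccc3c(NCCCNCc4ccco4)ccnc3c2)cc1` gives 32000 nM in this assay. Compound 2 `CC(C)(C)c1ccc(-c2ccc3c(NCCCNCc4ccco4)ccnc3c2)cc1` gives 32000 nM in this assay. Compound 3 `COc1ccc(F)cc1CNCCCNc1ccnc2cc(-c3ccc(C(C)(C)C)cc3)ccc12` gives 32000 nM in this assay. Compound 2 and compound 1 differ in one place, namely (trifluoromethyl in place of tert-butyl on an aromatic carbon), and that change made no change at the digits printed from compound 2 to compound 1 (within the scatter). Compound 2 and compound 3 differ in another place, namely (5-fluoro-2-methoxyphenyl in place of furan-2-yl on a saturated chain carbon bound to an amine nitrogen), and that change made no change at the digits printed from compound 2 to compound 3 (within the scatter). All three measured values therefore stand level with one another within the usual scatter of this assay.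

Compound 4 `COc1ccc(F)cc1CNCCCNc1ccnc2cc(-c3ccc(C(F)(F)F)cc3)ccc12` has not yet been measured. It differs from compound 3 in one place: trifluoromethyl in place of tert-butyl on an aromatic carbon. This is the same change that turns compound 2 into compound 1, and the place where it sits is described in identical words in both pairs, while the cores of compound 3 and compound 2 differ only in the way already described for compound 2 and compound 3. The earlier instance of this change left the solubility where it was.

Set beside no change at the digits printed from compound 2 to compound 1 (within the scatter), the step expected here is no change at the digits printed from compound 3 to compound 4 (within the scatter), and that expectation rests on the earlier step alone. Compound 4 is accordingly expected to give about 32000 nM in this assay, with a likely range from 16000 nM to 64000 nM.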

Compound 4, solubility: 32000 nM
For compound 4 middle estimate and measured number coincide at the digits printed, and the stated range covers the measured number.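

In this assay, trifluoromethyl in place of tert-butyl gives no change at the digits printed from compound 3 to compound 4 (within the scatter), and the same change on the core carrying furan-2-yl gave no change at the digits printed from compound 2 to compound 1 (within the scatter), so in these two pairs the change carries from one core to the other with the same outcome. The other change, 5-fluoro-2-methoxyphenyl in place of furan-2-yl, gives no change at the digits printed from compound 1 to compound 4 (within the scatter), which matches no change at the digits printed from compound 2 to compound 3 (within the scatter), so the four compounds close a square in which each change reads the same whichever group stands at the other place. This does not show that the change would behave alike on a core where the number moves, as two flat steps are only a narrow test, and nothing at hand explains the result.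

The compounds shown leave open what a carboxylic acid or a nitrile would do in the place of the trifluoromethyl, and what an amine-bearing group would do in the place of the furan-2-yl. They also leave open whether a longer chain linking the two nitrogens would shift the reading away from the level shared by all four compounds.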